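Working notes: compound 3 to compound 4 in cytotoxicity

A few compounds are considered here, and "the series" means these few. Any claim that something is new, unique, unknown or untested is made for them only; others in the source may bear on it.

Compound 1 `O=c1nc(N2CC[C@H](c3ccccc3)[C@@H](O)C2)sc2c([N+](=O)[O-])cc(C(F)(F)F)cc12` and compound 2 `O=c1nc(N2CC[C@@H](c3ccc(F)cc3)[C@H](CO)C2)sc2c([N+](=O)[O-])cc(C(F)(F)F)cc12` carry a hydroxy- or hydroxymethyl-bearing ring on the shared core. In a toxicity assay on HeLa cells (Homo sapiens) for cytotoxicity, read by colorimetric assay, with a stated time of 72 h (on this read-out lower numbers stand for higher toxicity in this test and higher numbers for lower toxicity in this test), compound 1 gives 73100 nM. In this assay compound 2 gives 35800 nM. Compound 3 `CC(=O)c1ccc(N2CCN(c3nc(=O)c4cc(C(F)(F)F)cc([N+](=O)[O-])c4s3)CC2)cc1` carries instead an aryl group on an amine nitrogen in a six-membered non-aromatic ring with two nitrogens. In this assay compound 3 gives > 105000 nM, which is a limit of the assay and not a number. The evidence on compound 3 is therefore only (the limit of > 105000 nM in this assay, at which 1 of the 3 values shown sits), and its place among the three values is known only as a bound.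

Compound 4 `N#Cc1ccccc1N1CCN(c2nc(=O)c3cc(C(F)(F)F)cc([N+](=O)[O-])c3s2)CC1` differs from compound 3 in one place: 2-cyanophenyl in place of 4-acetylphenyl on an amine nitrogen in a ring. Within the data shown here, no step between measured compounds matches this change, so it has no measured precedent here. Compound 4 is expected to stay near the limit, the expected step being an at least 1.0-fold lower number from compound 3 to compound 4 (0.02 log units; that floor lies within the scatter), none beyond the scatter. Compound 4 is estimated at 100000 nM, between 45000 nM and 220000 nM, and a limit rather than a number is about as likely as not.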

Compound 4, half-maximal cytotoxic concentration: > 108000 nM
Compound 4: no number, only a limit (the forecaster's own chance of this, stated with the estimate: 55%); middle value at least 1.0-fold (0.03 log units) away from the limit.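

In this assay, among these compounds, compound 4 gives > 108000 nM, a limit of the assay and not a number; compound 3 also stands only at a limit, so no step between compound 3 and compound 4 can be read. The compounds shown leave open whether 2-cyanophenyl in place of 4-acetylphenyl changes the read-out at all.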